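The source may report more compounds than this note shows. Statements on the series, on what has been measured and on what is new or still open speak of the compounds shown alone.

Measured so far:
compound 1 `COc1ccc2nc(NC(c3cn(-c4ccccc4)nc3-c3cccc([N+](=O)[O-])c3)c3c(O)ccc4ccccc34)sc2c1` in a functional assay on MCF7 cells (Homo sapiens) for antiproliferative activity, read by MTT assay, with a stated time of 48 h (on this read-out lower numbers stand for stronger inhibition and higher numbers for weaker inhibition), gives 26800 nM
compound 2 `COc1ccc2nc(NC(c3cn(-c4ccccc4)nc3-c3cccc(I)c3)c3c(O)ccc4ccccc34)sc2c1` in this assay gives 20000 nM

These two numbers lie within the scatter of each other, so compound 2 has no clear place ahead of or behind compound 1. Next is compound 3 `COc1ccc2nc(NC(c3cn(-c4ccccc4)nc3-c3ccccc3)c3c(O)ccc4ccccc34)sc2c1` with the change hydrogen in place of iodo on an aromatic carbon here, hydrogen in place of iodo on an aromatic carbon. Among the compounds with values here, the only measured step that bears on it is a 1.3-fold lower number from compound 1 to compound 2 (0.13 log units; within the scatter) at that same carbon, so no step beyond the scatter is expected in this assay and no direction is favoured. The estimated 1.2-fold higher number from compound 2 to compound 3 (0.06 log units; within the scatter) stays inside the scatter. The expected value for compound 3 is 23000 nM with an estimated range of 11000 nM to 50000 nM on this read-out.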

Compound 3, half-maximal inhibitory concentration: 40800 nM
The estimate for compound 3 lay 1.8-fold (0.25 log units) below the measured number; low and high end bracket the measured number.
By their numbers in this assay, from the lowest: compounds 2, 1 and 3 (each within the scatter of the next, the first and the last beyond it).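

In this assay, within the data shown here, removing the iodo group from its aromatic carbon gives the only step beyond the scatter (a 2.0-fold higher number from compound 2 to compound 3 (0.31 log units; beyond the scatter)), and that step is modest. Hydrogen in place of nitro at the same carbon stays within the scatter (a 1.5-fold higher number from compound 1 to compound 3 (0.18 log units; within the scatter)), so only compound 2 and compound 3 can be told apart. Nothing measured here explains the difference between the iodo group and hydrogen.

On these data alone, whether an amine or a carboxylic acid at this carbon would shift the number further remains open.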